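Urea-linked pyrazoles: removing a methyl

A few compounds are considered here, and "the series" means these few. Any claim that something is new, unique, unknown or untested is made for them only; others in the source may bear on it.

Measured so far:
compound 1 `O=C(Nc1cccc(-n2cc(-c3ccncc3)c(-c3ccc(Cl)c(O)c3)n2)c1)Nc1cccc(C(F)(F)F)c1` with 1810 nM
compound 2 `COc1cc(-c2nn(-c3cccc(NC(=O)Nc4ccc(Cl)c(Cl)c4)c3)cc2-c2ccncc2)ccc1Cl` with 926 nM

In a functional assay on Malme-3M cells (Homo sapiens) for inhibition, read by sulforhodamine B assay, with a stated time of 48 h (a lower number here means a stronger inhibitor of growth, a higher number a weaker inhibitor of growth), compound 2 stands at the lower of the two numbers, and compound 1 lies within the scatter of it. Compound 3 `O=C(Nc1cccc(-n2cc(-c3ccncc3)c(-c3ccc(Cl)c(O)c3)n2)c1)Nc1ccc(Cl)c(Cl)c1` differs from compound 2 by hydrogen in place of methyl on an oxygen on an aromatic ring. For the measured compounds named here, no single-change step between measured compounds is available, so the effect of this change is open; the expected step from compound 2 to compound 3 is a 1.4-fold higher number from compound 2 to compound 3 (0.15 log units; within the scatter), small and not clearly beyond the scatter. Compound 3 is therefore expected to give 1300 nM, with a range from 500 nM to 3500 nM.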

Compound 3, concentration for 50% growth inhibition: 1190 nM
Compound 3: middle estimate off by 1.1-fold (0.04 log units), on the high side, within the range that was stated.
By their numbers in this assay, from the lowest: compounds 2, 3 and 1 (each within the scatter of the next).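

In this assay, for the compounds shown here, compound 3 gives the first direct reading of this position: methoxy to hydroxy on the 4-chloro-3-methoxyphenyl group gives a 1.3-fold higher number from compound 2 to compound 3 (0.11 log units; within the scatter) and so does not separate the two compounds. On the amide-type nitrogen, 3,4-dichlorophenyl in place of 3-(trifluoromethyl)phenyl gives a 1.5-fold lower number from compound 1 to compound 3 (0.18 log units; within the scatter) and does not separate them either. No supporting measurement bears on either step.

The compounds shown leave open whether an ethoxy group or an amine at this place would give a step beyond the scatter. They also leave open how methoxy reads alongside 3-(trifluoromethyl)phenyl.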